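The source may report more compounds than this note shows. Statements on the series, on what has been measured and on what is new or still open speak of the compounds shown alone.

In a functional assay on HepG2 cells (Homo sapiens) for antiproliferative activity, read by MTT assay, with a stated time of 24 h (on this read-out lower numbers stand for stronger inhibition and higher numbers for weaker inhibition), compound 1 `Fc1ccc(C2CC(c3ccc(Cl)cc3)=NN2c2ccc(-c3ccccc3)nn2)cc1` gives 10000 nM and compound 3 `COc1ccc(C2=NN(c3ccc(-c4ccccc4)nn3)C(c3ccc(F)cc3)C2)cc1` gives 9160 nM. Compound 2 `COc1ccc(C2=NN(c3ccc(-c4ccccc4)nn3)C(c3ccc(Cl)cc3)C2)cc1` reaches only the limit of > 100000 nM in this assay. Among the numbers shown, compound 3 sits together with compound 1, the step of a 1.1-fold lower number from compound 1 to compound 3 (0.04 log units; within the scatter) separating them. Compound 4 `COc1ccc(C2=NN(c3ccc(-c4ccccc4)nn3)C(c3cc(OC)c(OC)c(OC)c3)C2)cc1` differs from compound 3 by 3,4,5-trimethoxyphenyl in place of 4-fluorophenyl on a saturated ring carbon. Going by the values given here, the only measured step at this saturated ring carbon is an at least 10-fold lower number from compound 2 to compound 3 (1.03 log units; beyond the scatter), a large step, so a change here can move the number far; yet no measured step covers a trimethoxyphenyl group, and the direction stays open. Compound 4 is therefore expected near 5000 nM, somewhere between 800 nM and 40000 nM, which would mean an expected 1.8-fold lower number from compound 3 to compound 4 (0.26 log units; within the scatter).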

Compound 4, half-maximal inhibitory concentration: > 100000 nM
Compound 4 was reported as a limit (the forecaster's own chance of this, stated with the estimate: 10%); middle value at least 20-fold (1.30 log units) from the limit.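

Putting 3,4,5-trimethoxyphenyl on this saturated ring carbon gives an at least 10-fold higher number from compound 3 to compound 4 (1.03 log units; beyond the scatter), so a second change here, and not only the swap of chloro for fluoro, moves the number far. Among the compounds carrying the 4-methoxyphenyl group, only the one with 4-fluorophenyl on this carbon gives a readable number. Compound 4 gives only a limit, and it shares that limit with one other compound: the limit of > 100000 nM in this assay, at which 2 of the 4 values shown sit.

Compound 2 and compound 4 both stand at limits, so the step between them cannot be read. On these data alone, whether a 4-aminophenyl or 4-carboxyphenyl group on this carbon would give a readable number stays open.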